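Sulfur to Oxygen Ether Swap on the Shared Core

The compounds below may be only part of what the source reports. "The series", "measured", "known", "first", "only" and "open" are said of these compounds alone.

Three compounds share a core and differ at one place. Compound 1 `COc1ccc(CNc2nc3cc(N)cc(N)c3nc2-c2ccccc2)cc1OC` gives 24500 nM in a functional assay on CAKI-1 cells (Homo sapiens) for inhibition, read by sulforhodamine B assay, with a stated time of 48 h; on this read-out higher numbers stand for weaker inhibition of growth and lower numbers for stronger inhibition of growth. Compound 2 `Nc1cc(N)c2nc(-c3ccccc3)c(NCc3ccc(F)cc3)nc2c1` gives 37200 nM, and compound 3 `COc1ccc(Sc2nc3cc(N)cc(N)c3nc2-c2ccccc2)cc1` gives 52500 nM. Compound 3 holds the highest of the three numbers; its gap to compound 2 is within the scatter, while its gap to compound 1 lies beyond it. The steps seen so far are a 1.5-fold higher number from compound 1 to compound 2 (0.18 log units; within the scatter) and a 1.4-fold higher number from compound 2 to compound 3 (0.15 log units; within the scatter), both within the scatter, so none of the changes tried at this position has moved the number clearly.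

Compound 4 `Nc1cc(N)c2nc(-c3ccccc3)c(Oc3ccc(F)cc3)nc2c1` is not yet measured. It differs from compound 3 by 4-fluorophenoxy in place of (4-methoxyphenyl)sulfanyl on an aromatic carbon. Among the measured compounds shown here, no measured step swaps an aryl thioether for an aryl ether, so the only guide is that every change tried at this position has stayed within the scatter. Compound 4 is therefore expected to stay close to compound 3, with the expected step being a 1.2-fold lower number from compound 3 to compound 4 (0.07 log units; within the scatter), no clear direction implied. The estimate for compound 4 is 45000 nM, with a range from 18000 nM to 110000 nM.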

Compound 4, concentration for total growth inhibition: 24500 nM
Compound 4: the middle estimate sits 1.8-fold (0.26 log units) above what was measured, within the range that was stated.
By their numbers in this assay, from the lowest: compounds 1, 4, 2 and 3 (each within the scatter of the next, the first and the last beyond it).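

In this assay, among the compounds shown here, the change to 4-fluorophenoxy from (4-methoxyphenyl)sulfanyl gives a 2.1-fold lower number from compound 3 to compound 4 (0.33 log units; beyond the scatter), so this position can move the number beyond the scatter in a single step, which neither step among the earlier compounds did. That step swaps the sulfur link for an oxygen link and the methoxy group for a fluorine together, while the swap of (4-fluorobenzyl)amino for 4-fluorophenoxy gives only a 1.5-fold lower number from compound 2 to compound 4 (0.18 log units; within the scatter), so those two groups remain unseparated. Nothing at hand bears on what lies behind the step.

Which part of the change carries the step stays open, and a 4-methoxyphenoxy or a (4-fluorophenyl)sulfanyl group at this position would separate the link from the ring substituent. On these data alone, how a morpholine or a carboxylic acid there would read in this assay also stays open.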